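Lipophilicity in a trifluoromethyl amino core series

The compounds below may be only part of what the source reports. "The series", "measured", "known", "first", "only" and "open" are said of these compounds alone.

Measured compounds:
compound 1 `CCN(CC)CCN(C)c1ccc(Cn2c(=O)[nH]c3c(N)nc(C(F)(F)F)cc32)cn1` 1.3
compound 2 `Nc1nc(C(F)(F)F)cc2c1[nH]c(=O)n2Cc1ccc(NCc2ccccc2)nc1` 1.8

In a physicochemical assay for lipophilicity (on this read-out higher numbers stand for higher lipophilicity and lower numbers for lower lipophilicity), compound 2 stands highest of the two numbers; its nearest neighbour is compound 1, which sits a number 0.50 log units higher from compound 1 to compound 2 (beyond the scatter) below it. Compound 3 `CN(CCN1CCCCC1)c1ccc(Cn2c(=O)[nH]c3c(N)nc(C(F)(F)F)cc32)cn1` is not yet measured. It differs from compound 2 as follows: methyl(2-(piperidin-1-yl)ethyl)amino in place of benzylamino on an aromatic carbon. Among the compounds with values here, the one step that bears on this change is the one between compound 1 and compound 2, where benzylamino in place of (2-(diethylamino)ethyl)(methyl)amino gave a number 0.50 log units higher from compound 1 to compound 2 (beyond the scatter). Compound 3 carries methyl(2-(piperidin-1-yl)ethyl)amino, which resembles the group in compound 1 more closely than the benzylamino of compound 2, so a downward step of similar size, somewhat softened, is expected: a number 0.30 log units lower from compound 2 to compound 3 (within the scatter). Compound 3 is therefore estimated at 1.5 in this assay, in a range from 1.1 to 1.9, close to the value of compound 1.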

Compound 3, distribution coefficient: 1.8
Compound 3: middle estimate off by 0.30 log units, on the low side, within the range that was stated.
By their numbers in this assay, from the lowest: compound 1; then compounds 2 and 3 (each within the scatter of the next).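

At the aromatic carbon next to the ring nitrogen, this assay shows no change at the digits printed from compound 2 to compound 3 (within the scatter) when methyl(2-(piperidin-1-yl)ethyl)amino replaces benzylamino, so among these compounds a six-membered aromatic ring of carbon only in this substituent is not needed to reach this level. The chain-bearing substituents of compound 1 and compound 3 do not read alike: piperidin-1-yl in place of diethylamino, two bonds along the chain from the nitrogen on the aromatic ring, gives a number 0.50 log units higher from compound 1 to compound 3 (beyond the scatter), so the earlier step from benzylamino does not hold for every such chain. The compounds come with no evidence that accounts for either step.

This chain-end comparison rests on a single pair of compounds. As far as these compounds go, whether a morpholine or pyrrolidine at the chain end, or a longer chain between the two nitrogens, would follow compound 3 or compound 1 remains open.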